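The compounds below may be only part of what the source reports. "The series", "measured", "known", "first", "only" and "open" are said of these compounds alone.

Working notes on the sulfonyl- and acyl-azetidine oxadiazoles

Three compounds have been run in an assay on HEK293 cells for negative allosteric modulation of metabotropic glutamate receptor 5 (Homo sapiens), read by FLIPR; on this read-out lower numbers stand for stronger inhibition and higher numbers for weaker inhibition. Compound 1, `Cc1cccc(-c2noc(C3CN(S(=O)(=O)c4cccc(C)c4)C3)n2)c1`, gives 650 nM in this assay. Compound 2, `Cc1cccc(S(=O)(=O)N2CC(c3nc(-c4cccc(Cl)c4)no3)C2)c1`, carries the change chloro in place of methyl on an aromatic carbon relative to compound 1; in this assay compound 2 gives 390 nM, and the step of a 1.7-fold lower number from compound 1 to compound 2 (0.22 log units; within the scatter) is a small one, so the two numbers cannot be told apart with confidence. Compound 3, `Cc1cccc(-c2noc(C3CN(C(=O)c4ccccc4F)C3)n2)c1`, gives 1400 nM, the highest of the three numbers, and its distance from compound 1 and from compound 2 lies beyond the scatter in each case. The difference between the core of compound 3 and the core of compound 1 is not broken down here.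

Compound 4, `O=C(c1ccccc1F)N1CC(c2nc(-c3cccc(Cl)c3)no2)C1`, has not yet been measured in this assay. It differs from compound 3 by chloro in place of methyl on an aromatic carbon, which is the same change that took compound 1 to compound 2; the surroundings of the place are described in identical words for the two pairs. Going by the values given here, the step from compound 3 to compound 4 is expected to be a 1.6-fold lower number from compound 3 to compound 4 (0.19 log units; within the scatter), an estimate that rests on the single earlier instance, a 1.7-fold lower number from compound 1 to compound 2 (0.22 log units; within the scatter), which was within the scatter and so gives no firm direction. On that basis compound 4 is expected to give about 900 nM, with a plausible range from 450 nM to 1800 nM.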

Compound 4, half-maximal inhibitory concentration: 670 nM
Estimate against measurement, compound 4: 1.3-fold (0.13 log units) above; the measured number falls inside the stated range.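

On the core of compound 3, chloro in place of methyl gives a 2.1-fold lower number from compound 3 to compound 4 (0.32 log units; beyond the scatter) in this assay, a modest step that, taken alone, can be told from the scatter. Set beside the earlier step on the core of compound 1, it points the same way and cannot be told apart from that step in size, so within these two pairs the change carries from the sulfonyl compounds to the carbonyl compounds without a detectable difference: the same change on two cores in this assay, a 1.7-fold lower number (0.22 log units; within the scatter) from compound 1 to compound 2 and a 2.1-fold lower number (0.32 log units; beyond the scatter) from compound 3 to compound 4, 1.3-fold (0.10 log units) apart, within the scatter of two such steps. Going by these compounds alone, this rests on only two pairs, one of which stays within the scatter by itself, so it shows agreement between these two cores only and gives no general rule for the series, nor any reason for the shift.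

Open, going by these compounds, is how a nitrile or a methoxy group at the same place on the aromatic ring would read in this assay when set against methyl and chloro. Also open, on these data alone, is whether the same change would carry to a core with an amine or a longer chain in place of the sulfonyl or the carbonyl.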